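The compounds below may be only part of what the source reports. "The series", "measured", "known", "first", "only" and "open" are said of these compounds alone.

In a functional assay for inhibition, with Homo sapiens as the target (a lower number here means a stronger inhibitor, a higher number a weaker inhibitor), compound 1 `CC(C)(C)Sc1c(CC(C)(C)C(=O)O)n(Cc2ccc(Cl)cc2)c2ccc(OCc3ccc4cc(F)ccc4n3)cc12` gives 2 nM and compound 2 `CC(C)(C)Sc1c(CC(C)(C)C(=O)O)n(Cc2ccc(Cl)cc2)c2ccc(OCc3cc4ccccc4cn3)cc12` gives 3 nM. These two numbers lie within the scatter of each other, so compound 2 stands level with compound 1 on the data so far.

The next change leads to compound 3 `CC(C)(C)Sc1c(CC(C)(C)C(=O)O)n(Cc2ccc(Cl)cc2)c2ccc(OCc3ccc4cnccc4n3)cc12`: a group of 10 heavy atoms (8 carbon, 2 nitrogen; 2 six-membered aromatic rings with 1 hetero atom each) in place of a group of 10 heavy atoms (9 carbon, 1 nitrogen; one six-membered aromatic ring of carbon only, one six-membered aromatic ring with 1 hetero atom), on a saturated chain carbon bound to an oxygen on an aromatic ring. Among the compounds with values here, the ring of carbon only in the group that leaves has no counterpart in the group that enters, where both rings carry a hetero atom.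

Within the data shown here, one measured step bears on this change, at the same place on the shared core: a 1.5-fold higher number from compound 1 to compound 2 (0.18 log units; within the scatter). That step exchanged one bicyclic group for another without a shift beyond the scatter. Among the measured compounds shown here, no measured pair yet tests a group with a hetero atom in both rings, so this evidence is indirect and the range is kept wide. On that single step, no shift beyond the scatter is expected in this assay.

The estimated step is a 1.3-fold higher number from compound 2 to compound 3 (0.12 log units; within the scatter), which is expected to stay within the scatter. For compound 3 the estimated value is 4 nM, with an expected range of 1.5 nM to 15 nM.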

Compound 3, half-maximal inhibitory concentration: 3 nM
The estimate for compound 3 lay 1.3-fold (0.12 log units) above the measured number, within the range that was stated.
By their numbers in this assay, from the lowest: compounds 1, 2 and 3 (each within the scatter of the next).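

In this assay, replacing isoquinolin-3-yl with the group that has a hetero atom in both rings gives no change at the digits printed from compound 2 to compound 3 (within the scatter), while replacing 6-fluoroquinolin-2-yl with that same group gives a 1.5-fold higher number from compound 1 to compound 3 (0.18 log units; within the scatter). Among the compounds shown, a six-membered aromatic ring of carbon only is therefore not required at this place, on a saturated chain carbon bound to an oxygen on an aromatic ring, for the number to stay level with those of compound 1 and compound 2. The same holds when the fluorine of compound 1 is absent and a second ring nitrogen is present, but nothing measured here accounts for these three groups standing level.

All three groups are bicyclic aromatic groups, and their numbers lie within the scatter of one another, so the compounds shown mark no limit to what this place accepts. On these data alone, it remains open whether a single pyridine ring, a plain phenyl ring or a bicyclic group carrying an amine would hold the number at this level in this assay.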